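The compounds below may be only part of what the source reports. "The series", "measured", "known", "first", "only" and "open" are said of these compounds alone.

Compound 1 `COC(=O)C1=C(C)N(c2ccc(OC)cc2)C=C(C)C1c1ccccc1` and compound 2 `COC(=O)C1=C(C)N(c2cccc(Cl)c2)C=C(C)C1c1ccccc1` share one core and differ only in the aromatic group on the amine nitrogen in the ring. In a functional assay, tested at 200 ug/mL (on this read-out higher numbers stand for a weaker effect at the one concentration tested and lower numbers for a stronger effect), compound 1 gives -34.7%, and compound 2 gives -35.3%. The step of a number 0.6 percentage points lower from compound 1 to compound 2 (within the scatter) shows that swapping one aromatic group on that nitrogen for another produced no difference beyond the scatter. On the numbers shown, compound 2 has the more negative of the two values, but its gap to compound 1 lies within the scatter, so the two cannot be told apart. Compound 3 `COC(=O)C1=C(C)N(c2cccc(C)c2C)C=C(C)C1c1ccccc1` has not yet been measured; it differs from compound 2 by 2,3-dimethylphenyl in place of 3-chlorophenyl on an amine nitrogen in a ring. Within the data shown here, the only measured step that bears on this change is a number 0.6 percentage points lower from compound 1 to compound 2 (within the scatter), which was within the scatter, so in this assay no step beyond the scatter is expected for compound 3 either. The expected step is a number 0.3 percentage points higher from compound 2 to compound 3 (within the scatter). Compound 3 is therefore estimated at -35%, with a range from -52% to -18%.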

Compound 3, a percentage reported as activity, at one concentration (the size of the read-out at that concentration, not a potency): -32.2%
Beside the measured number, compound 3's estimate is 2.8 percentage points below it; low and high end bracket the measured number.
By their numbers in this assay, from the lowest: compounds 2, 1 and 3 (each within the scatter of the next).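

With 2,3-dimethylphenyl as a third aromatic group on the amine nitrogen in the ring, this assay still shows no step beyond the scatter: it gives a number 3.1 percentage points higher from compound 2 to compound 3 (within the scatter), and a number 2.5 percentage points higher from compound 1 to compound 3 (within the scatter). So, among these three compounds, two methyl groups on that aromatic ring read the same as a single chlorine or a single methoxy group, which extends the flat picture from one change to three different groups. Nothing available explains why these groups read alike.

Still open, going by these compounds, is whether this position stays as flat with a group of a different kind, such as an aromatic ring carrying an amine or a carboxylic acid, or a longer chain in place of the ring. The compounds shown also leave open what changes at the methoxycarbonyl and phenyl groups would do, as these stay the same throughout.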